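The source may report more compounds than this note shows. Statements on the series, on what has been measured and on what is new or still open speak of the compounds shown alone.

Measured compounds:
compound 1, `Fc1cc(Nc2nc3nonc3nc2Nc2ccc(C(F)(F)F)c(F)c2)ccc1C(F)(F)F`: 1700 nM
compound 2, `Fc1cc(I)ccc1Nc1nc2nonc2nc1Nc1ccc(I)cc1F`: 8800 nM
compound 3, `Fc1ccccc1Nc1nc2nonc2nc1Nc1ccccc1`: 2200 nM

All three were tested in an assay on mitochondria from L6 cells (Rattus norvegicus) for activation, with a stated time of 90 min; a lower number here means that less compound is needed, a higher number that more compound is needed for the effect. Compound 3 stands second highest of the three numbers: its value lies within the usual scatter of the value of compound 1, so no order between those two can be claimed, while the value of compound 2 lies beyond the scatter above it. Compound 4, `Fc1ccccc1Nc1nc2nonc2nc1NCCC(F)(F)F`, has not yet been measured. It differs from compound 3 in one place: 3,3,3-trifluoropropyl in place of phenyl on a nitrogen on an aromatic ring. Every measured compound carries two aromatic rings on the two nitrogens of the shared core, so nothing measured shows what happens when one of them gives way to a chain. Compound 4 is therefore expected to need more compound than compound 3, a step of moderate size beyond the scatter, and the step from compound 3 to compound 4 is estimated at a 2.7-fold higher number from compound 3 to compound 4 (0.44 log units; beyond the scatter). For compound 4 the expected value in this assay is 6000 nM, with a range from 2000 nM to 20000 nM.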

Compound 4, half-maximal effective concentration: > 100000 nM
Compound 4 was reported as a limit; the forecaster's own chance of this, stated with the estimate: 15%; middle value at least 16-fold (1.22 log units) away from the limit.
By their numbers in this assay, from the lowest: compounds 1 and 3 (each within the scatter of the next); then compound 2. At a limit, above all of these: compound 4.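

In this assay the nitrogen on an aromatic ring proves not to tolerate every group of the same heavy-atom count: 3,3,3-trifluoropropyl in place of phenyl gives an at least 45-fold higher number from compound 3 to compound 4 (1.65 log units; beyond the scatter), whereas the three earlier compounds, all with an aromatic ring on both nitrogens, left this change untested. Compound 4 is reported only as a limit (> 100000 nM), so the step has a floor but no known upper end: the limit of > 100000 nM in this assay, at which 1 of the 4 values shown sits. This single pair cannot separate the loss of the aromatic ring from the arrival of the fluorine atoms.

The compounds shown leave open whether a plain propyl chain, a benzyl group or a cyclohexyl ring on this nitrogen would behave in the same way. They also leave open whether a chain on the other nitrogen of the shared core would give the same result.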